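Moving the formyl group around the phenoxy ring

A few compounds are considered here, and "the series" means these few. Any claim that something is new, unique, unknown or untested is made for them only; others in the source may bear on it.

Of the compounds shown here, two have so far been measured in a functional assay on HT-29 cells (Homo sapiens) for cytotoxicity, read by MTT assay, with a stated time of 24 h; a lower number here means a stronger inhibitor, a higher number a weaker inhibitor. Compound 1 `O=Cc1ccccc1OCc1cn(CCCOc2ccc3ccc(=O)oc3c2)nn1` gives 18900 nM, while compound 2 `O=Cc1cccc(OCc2cn(CCCOc3ccc4ccc(=O)oc4c3)nn2)c1` gives 129000 nM. Within the data shown here, the only measured step, a 6.8-fold higher number from compound 1 to compound 2 (0.83 log units; beyond the scatter), is the exchange of 2-formylphenyl for 3-formylphenyl on an oxygen on a saturated carbon, and it leaves compound 2 with the highest of the two numbers, its nearest neighbour being compound 1.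

Compound 3 `O=Cc1ccc(OCc2cn(CCCOc3ccc4ccc(=O)oc4c3)nn2)cc1` is the next member of this series. It differs from compound 2 by 4-formylphenyl in place of 3-formylphenyl on an oxygen on a saturated carbon whose other neighbour is a saturated chain carbon. Among the measured compounds shown here, no measured step describes this exact change; the step from compound 1 to compound 2 shows only that moving the formyl group around this ring can shift the number by a modest amount. With no closer guide, compound 3 is expected to stay near compound 2, with an expected step of a 1.6-fold lower number from compound 2 to compound 3 (0.21 log units; within the scatter) in this assay . Compound 3 is therefore estimated at 80000 nM, within a range from 25000 nM to 250000 nM.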

Compound 3, half-maximal inhibitory concentration: 100000 nM
Estimate against measurement, compound 3: 1.3-fold (0.10 log units) below; measured number inside the range.
By their numbers in this assay, from the lowest: compound 1; then compounds 3 and 2 (each within the scatter of the next).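

In this assay, the exchange of 3-formylphenyl for 4-formylphenyl on an oxygen on a saturated carbon gives a 1.3-fold lower number from compound 2 to compound 3 (0.11 log units; within the scatter), so these two placements of the formyl group cannot be told apart here. The other new comparison, a 5.3-fold higher number from compound 1 to compound 3 (0.72 log units; beyond the scatter), shows that 2-formylphenyl stands apart from 4-formylphenyl as well as from 3-formylphenyl, which leaves compound 1 as the strongest of the three, with compound 2 and compound 3 together behind it. No measurement offered here explains this difference in the position of the formyl group.

On these data alone, all three compounds carry a formyl group, so it remains open whether a carboxylic acid, a nitrile or a hydroxymethyl group in its place on the 2-substituted ring would keep the number of compound 1 or lose it. As far as these compounds go, it is also open whether a longer chain in the shared core would preserve the gap that separates compound 1 from compound 2 and compound 3.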